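Bromo step on the amide of the series

A few compounds are considered here, and "the series" means these few. Any claim that something is new, unique, unknown or untested is made for them only; others in the source may bear on it.

In a functional assay (uterus) for inhibition, with Rattus norvegicus as the target (a higher number here means that more compound is needed for the effect, a lower number that less compound is needed), compound 1 `CCOC(=O)c1cn2c(Br)cncc2n1` gives 1.02 nM. Compound 2 `NC(=O)c1cn2ccncc2n1` gives 1.5 nM, the higher of the two numbers, but within the scatter of compound 1, so the pair cannot be ranked. Compound 3 `NC(=O)c1cn2c(Br)cncc2n1` differs from compound 2 by bromo in place of hydrogen on an aromatic carbon. Among the compounds with values here, no measured pair shows this change alone. In this assay, no step beyond the scatter is expected, and the estimated step of a 1.3-fold lower number from compound 2 to compound 3 (0.10 log units; within the scatter) is small. For compound 3, the estimated value is 1.2 nM, with an expected range of 0.4 nM to 3.6 nM.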

Compound 3, concentration for half-maximal effect: 0.41 nM
Beside the measured number, compound 3's estimate is 2.9-fold (0.47 log units) above it; low and high end bracket the measured number.
By their numbers in this assay, from the lowest: compound 3; then compounds 1 and 2 (each within the scatter of the next).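

In this assay, within the data shown here, bromo in place of hydrogen on an aromatic carbon, next to the ring nitrogen, gives a 3.7-fold lower number from compound 2 to compound 3 (0.56 log units; beyond the scatter), the first single change to go beyond the scatter. With the bromo kept, amino in place of ethoxy on a carbonyl carbon gives a 2.5-fold lower number from compound 1 to compound 3 (0.40 log units; beyond the scatter), leaving compound 3 with the lowest number of the three. Nothing available explains either step. From the compounds shown here alone, whether chloro or methyl at this place gives a similar step remains open. So does the effect of a methylamino group or a carboxylic acid on the carbonyl carbon.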